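This account rests on a few compounds, and the source may have more. Where it says the series, first, only, none or still open, it means among the compounds named here.

Compound 1 `O=C(N/N=C/c1cc(I)cc(I)c1O)c1ccccc1`: > 50000 nM
Compound 2 `Cc1ccc(C(=O)N/N=C/c2cc(I)cc(I)c2O)cc1`: > 25000 nM
Compound 3 `O=C(N/N=C/c1cc(I)c(O)c(I)c1)c1ccccc1`: 191000 nM

All three were tested in a functional assay on HepG2 cells (Homo sapiens) for cytotoxicity, with a stated time of 24 h; a lower number here means a stronger inhibitor, a higher number a weaker inhibitor. For compound 1 the result is not a number but a limit of the assay, (the limit of > 50000 nM in this assay, at which 1 of the 3 values shown sits). For compound 2 the result is likewise only a limit, (the limit of > 25000 nM in this assay, at which 1 of the 3 values shown sits). Within the data shown here, compound 3 is the one compound with a definite number, and in this assay compound 3 gives 191000 nM, a weak effect on cell survival.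

Compound 1 and compound 2 differ in one place: methyl in place of hydrogen on an aromatic carbon. The step this change made, a step that the two limits leave unreadable from compound 1 to compound 2, cannot be read, since both ends are limits. Compound 3 is built from the same atoms as compound 1, joined differently; the difference between the two cores is not broken down here.

The unmeasured compound 4 `Cc1ccc(C(=O)N/N=C/c2cc(I)c(O)c(I)c2)cc1` relates to compound 3 exactly as compound 2 relates to compound 1: methyl in place of hydrogen on an aromatic carbon. The place of the change is described in the same words for both pairs, so it is the same change. Among the measured compounds shown here, with the earlier step unreadable, the expectation for compound 4 rests on compound 3 alone, whose value 191000 nM is the only number available. Compound 4 is expected to stay close to compound 3, with an estimated step of a 1.3-fold lower number from compound 3 to compound 4 (0.10 log units; within the scatter). The estimate for compound 4 in this assay is 150000 nM, expected to lie between 50000 nM and 400000 nM.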

Compound 4, half-maximal inhibitory concentration: > 100000 nM
Compound 4: only a limit was reported; the forecaster's own chance of this, stated with the estimate: 35%; the middle value does not contradict the limit.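

In this assay compound 4 gives only a limit of the assay, not a number: the limit of > 100000 nM in this assay, at which 1 of the 4 values shown sits.

Among these compounds, the step from compound 3 to compound 4 therefore cannot be read, so no step between compounds 1, 2, 3 and 4 has a size. On these data alone, what stays open is whether methyl in place of hydrogen on an aromatic carbon changes the result in this assay at all, on either core.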